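This account rests on a few compounds, and the source may have more. Where it says the series, first, only, none or still open, it means among the compounds named here.

Measured so far in an ADME assay on HepG2 cells (Homo sapiens) for cytotoxicity, read by MTT assay, with a stated time of 72 h; on this read-out lower numbers stand for higher toxicity in this test and higher numbers for lower toxicity in this test:
- compound 1 `Cc1nc2c(Sc3ccc(Cl)cc3)cc(Cl)cn2c1[N+](=O)[O-]` gives > 7800 nM
- compound 2 `O=[N+]([O-])c1cnc2c(Br)cc(Cl)cn12` gives 16200 nM

Two compounds carry a value in this assay. For compound 1 the result is a limit of the measurement and not a number, as recorded in the limit of > 7800 nM in this assay, at which 1 of the 2 values shown sits. Compound 2 gives a full number, at the weakly toxic end of the read-out. Going by the values given here, no step between measured compounds that differ in one place is available, so where compound 1 stands is known only as a limit, and the pair with compound 2 shows no more than that neither reaches strong toxicity here.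

Compound 3 `O=[N+]([O-])c1c(CS(=O)(=O)C2CCCCC2)nc2c(Sc3ccc(Cl)cc3)cc(Cl)cn12` is not yet measured. It differs from compound 1 by cyclohexylsulfonyl in place of hydrogen on a saturated chain carbon bound to an aromatic carbon. With compound 1 known only as a limit, nothing in the measured set fixes the size of this change; in this assay a step not beyond the usual scatter, in no set direction, is expected. The expected step is a step that the limit leaves unreadable from compound 1 to compound 3. Compound 3 is estimated at 10000 nM, with a range from 3000 nM to 40000 nM.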

Compound 3, half-maximal cytotoxic concentration: > 31200 nM
Compound 3: no number, only a limit; the forecaster's own chance of this, stated with the estimate: 45%; middle value at least 3.1-fold (0.49 log units) away from the limit.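

In this assay compound 3 gives > 31200 nM, a limit and not a number. Compound 1 gives > 7800 nM, also a limit. No step can be read between compound 1 and compound 3. Still open, on these data alone, is whether cyclohexylsulfonyl in place of hydrogen on a saturated chain carbon bound to an aromatic carbon shifts the read-out at all, and in which direction.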